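The source may hold more compounds than are shown below. What is called first, only, known or untested is meant among the compounds shown, and "the series" means these compounds.

Measured compounds:
compound 1, `COc1ccc(/C=C/C(=O)c2ccccc2-c2ccc(F)cc2)cc1`, 670 nM; compound 2, `COc1ccc(/C=C/C(=O)c2ccccc2-c2ccc(F)nc2)cc1`, 2700 nM; compound 3, `COc1ccc(C(=O)/C=C/c2ccccc2-c2ccc(F)cc2)cc1OC`, 7100 nM.

In a functional assay on MCF7 cells (Homo sapiens) for antiproliferative activity, read by sulforhodamine B assay, with a stated time of 48 h (on this read-out higher numbers stand for weaker inhibition and lower numbers for stronger inhibition), compound 1 gives 670 nM. Compound 2 differs from it by one change, (6-fluoropyridin-3-yl in place of 4-fluorophenyl on an aromatic carbon), and in this assay compound 2 gives 2700 nM, so that a 4.0-fold higher number from compound 1 to compound 2 (0.61 log units; beyond the scatter). Compound 3 carries a different core, and the difference between the two cores is not broken down here; in this assay compound 3 gives 7100 nM, the highest number of the three.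

Compound 4, `COc1ccc(C(=O)/C=C/c2ccccc2-c2ccc(F)nc2)cc1OC`, has not been measured. It is related to compound 3 by the same change that relates compound 2 to compound 1: 6-fluoropyridin-3-yl in place of 4-fluorophenyl on an aromatic carbon. Since that change, made once, gave a 4.0-fold higher number from compound 1 to compound 2 (0.61 log units; beyond the scatter), a step of a similar size is expected from compound 3 to compound 4 in this assay, namely a 3.4-fold higher number from compound 3 to compound 4 (0.53 log units; beyond the scatter). Whether the new core of compound 3 carries the change in the same way is not known from these three compounds alone, so the range is kept wide. Compound 4 is therefore estimated at 24000 nM, with a likely span from 8000 nM to 70000 nM.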

Compound 4, half-maximal inhibitory concentration: 41000 nM
Compound 4: middle estimate off by 1.7-fold (0.23 log units), on the low side; the range from low to high includes it.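

In this assay, the change from 4-fluorophenyl to 6-fluoropyridin-3-yl also raises the number on the second core, with a 5.8-fold higher number from compound 3 to compound 4 (0.76 log units; beyond the scatter). Set beside the earlier step, the two results agree: the same change on two cores in this assay, a 4.0-fold higher number (0.61 log units; beyond the scatter) from compound 1 to compound 2 and a 5.8-fold higher number (0.76 log units; beyond the scatter) from compound 3 to compound 4, 1.4-fold (0.16 log units) apart, within the scatter of two such steps. For these two pairs, the size of the step therefore carried over from one core to the other, but two pairs cannot show that it would hold on any further core, and they do not explain why the number rises.

The compounds shown leave open how a pyridine ring without the fluorine, or one with an amine or a methoxy group in place of that fluorine, would behave on either core. As far as these compounds go, the two cores also differ in more than one place, and how much each difference contributes to the gap between compound 1 and compound 3 remains unknown.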